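Changing the Carbamate Substituent: From Compound 3 to Compound 4

The source may report more compounds than this note shows. Statements on the series, on what has been measured and on what is new or still open speak of the compounds shown alone.

Measured in an assay on membranes from brain for inhibition of sphingomyelin phosphodiesterase 2 (Rattus norvegicus), using microsomes; on this read-out lower numbers stand for stronger inhibition and higher numbers for weaker inhibition:
Compound 1, `CCCCCCCCCCCCC/C=C/[C@@H](O)[C@H](COC(=O)NCCCN(C)C)NC(=O)C(C)(C)C`: 4900 nM
Compound 2, `CCCCCCCCCCCCC/C=C/[C@@H](O)[C@H](COC(=O)NCC[N+](C)(C)C)NC(=O)C(C)(C)C`: 8700 nM
Compound 3, `CCCCCCCCCCCCC/C=C/[C@@H](O)[C@H](COC(=O)Nc1ccccn1)NC(=O)C(C)(C)C`: 7900 nM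

Compound 3 gives the second highest of these three numbers, yet all three lie within the usual scatter of one another; the steps that lead to it are a 1.6-fold higher number from compound 1 to compound 3 (0.21 log units; within the scatter) and a 1.1-fold lower number from compound 2 to compound 3 (0.04 log units; within the scatter).

Compound 4, `CCCCCCCCCCCCC/C=C/[C@@H](O)[C@H](COC(=O)NCc1cccnc1)NC(=O)C(C)(C)C`, differs from compound 3 in one place: (pyridin-3-yl)methyl in place of pyridin-2-yl on an amide-type nitrogen. The measured steps that bear on this, a 1.8-fold higher number from compound 1 to compound 2 (0.25 log units; within the scatter) and a 1.6-fold higher number from compound 1 to compound 3 (0.21 log units; within the scatter), also exchanged only the group on the amide-type nitrogen of the carbamate and stayed within the scatter. No step beyond the scatter is therefore expected in this assay; the expected step is a 1.1-fold lower number from compound 3 to compound 4 (0.05 log units; within the scatter). Compound 4 is estimated at 7000 nM, with a range from 3000 nM to 18000 nM.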

Compound 4, half-maximal inhibitory concentration: 2100 nM
For compound 4 the middle estimate is 3.3-fold (0.52 log units) above the measured one; the measured number lies below the stated range.
By their numbers in this assay, from the lowest: compound 4; then compounds 1, 3 and 2 (each within the scatter of the next).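

Earlier exchanges on the amide-type nitrogen stayed within the scatter, but in this assay this position does respond: (pyridin-3-yl)methyl in place of pyridin-2-yl gives a 3.8-fold lower number from compound 3 to compound 4 (0.58 log units; beyond the scatter). The same group also stands apart from the open-chain groups, with a 4.1-fold lower number from compound 2 to compound 4 (0.62 log units; beyond the scatter) and a 2.3-fold lower number from compound 1 to compound 4 (0.37 log units; beyond the scatter). Nothing measured here says why the number fell.

On these data alone, this single exchange alters both the pyridine attachment and the carbon link, so their separate contributions stay unknown. As far as these compounds go, how (pyridin-2-yl)methyl or plain benzyl would read remains open.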